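The compounds below may be only part of what the source reports. "The series", "measured", "known", "first", "only" and "open" are said of these compounds alone.

Measured compounds:
compound 1, `O=C1[C@@H](NS(=O)(=O)c2ccc(Oc3ccc(Cl)cc3)cc2)CC=CCN1O`, 1120 nM
compound 2, `O=C1[C@H](NS(=O)(=O)c2ccc(Oc3ccc(Cl)cc3)cc2)CC=CCN1O`, 0.58 nM

Compound 2 holds the lowest of the two numbers in an assay on isolated protein for inhibition of matrix metalloproteinase-9 (Homo sapiens), read by fluorescence, with stated times of 1 h and 15 min; a lower number here means a stronger inhibitor, a higher number a weaker inhibitor; its nearest neighbour is compound 1, which differs from it only in the configuration drawn at a saturated ring carbon, and the step between them is a 1900-fold lower number from compound 1 to compound 2 (3.29 log units; beyond the scatter). That the two share every atom and bond the fact that compounds 1 and 2 differ only in the configuration as drawn is the whole of what separates their numbers.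

Compound 3, `O=C1[C@H](NS(=O)(=O)c2ccc(Oc3ccccc3)cc2)CC=CCN1O`, has not yet been measured in this assay. It departs from compound 2 by hydrogen in place of chloro on an aromatic carbon, para to a large group. No measured step touches this part of the molecule: the only step shown concerns configuration at the ring carbon and says nothing about the chloro. The expectation therefore rests on the change itself. Loss of the chloro is expected to give a modestly higher number, a step of a 4.3-fold higher number from compound 2 to compound 3 (0.63 log units; beyond the scatter), with compound 3 estimated at 2.5 nM, within a range of 0.6 nM to 12 nM.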

Compound 3, half-maximal inhibitory concentration: 2 nM
Estimate against measurement, compound 3: 1.3-fold (0.10 log units) above; the measured number falls inside the stated range.
By their numbers in this assay, from the lowest: compound 2; then compound 3; then compound 1.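

Replacing chloro with hydrogen on the aromatic carbon para to a large group, the change from 4-chlorophenoxy to phenoxy, gives a 3.4-fold higher number from compound 2 to compound 3 (0.54 log units; beyond the scatter) in this assay, a modest step, though one that lies beyond the scatter. Within the data shown here, this is the first reading at this place on the molecule: the number stays low without the chloro, with compound 3 at 2 nM, so the chloro is not needed for a low number here, even though it is linked to a measurable gain. The step is also far smaller than the one seen on changing the configuration at the saturated ring carbon, a 1900-fold lower number from compound 1 to compound 2 (3.29 log units; beyond the scatter), and nothing given here accounts for the effect of the chloro.

The compounds shown carry only chloro or hydrogen at this place, so it remains open how a fluoro, bromo, methoxy or trifluoromethyl group would read there in this assay. Also open is whether the chloro step would keep its size with the configuration drawn in compound 1, as no pair shown tests this.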